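This account rests on a few compounds, and the source may have more. Where it says the series, first, only, none or still open, it means among the compounds named here.

Compound 1 `O=C1C[C@H](OCc2cn(Cc3ccccc3)nn2)[C@H]2CO[C@@H]1O2`: > 50000 nM
Compound 2 `COC(=O)Cn1cc(CO[C@H]2CC(=O)[C@@H]3OC[C@H]2O3)nn1`: 21300 nM
Compound 3 `O=C1C[C@H](OCc2cn(-c3ccc(F)cc3)nn2)[C@H]2CO[C@@H]1O2`: 23700 nM

In a functional assay on MDA-MB-231 cells (Homo sapiens) for cytotoxicity, read by MTT assay, with a stated time of 48 h (on this read-out higher numbers stand for weaker inhibition and lower numbers for stronger inhibition), compound 1 gives only a limit of the assay, > 50000 nM. In the same assay compound 2 gives 21300 nM, and compound 3 gives 23700 nM. Compound 1 thus stands at the edge of what the assay reports, (the limit of > 50000 nM in this assay, at which 1 of the 3 values shown sits), while compound 2 and compound 3 sit inside the measured range. Both measured steps away from compound 1 lower the number: an at least 2.3-fold lower number from compound 1 to compound 2 (0.37 log units; beyond the scatter) and an at least 2.1-fold lower number from compound 1 to compound 3 (0.32 log units; beyond the scatter). Between compound 2 and compound 3 there is no real difference, a 1.1-fold higher number from compound 2 to compound 3 (0.05 log units; within the scatter).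

Compound 4 `O=C1C[C@H](OCc2cn(-c3ccccc3Br)nn2)[C@H]2CO[C@@H]1O2` differs from compound 1 by 2-bromophenyl in place of benzyl on an aromatic nitrogen. The closest measured precedent is the step to compound 3, in which a 4-fluorophenyl likewise took the place of the benzyl on the aromatic nitrogen and the number fell past the limit. On that basis a modest lowering is expected, an at least 1.9-fold lower number from compound 1 to compound 4 (0.28 log units; that floor lies within the scatter). Compound 4 is therefore estimated at 26000 nM, within a range from 10000 nM to 60000 nM. For the measured compounds named here, only one aryl-for-benzyl step has been measured, and no compound tests where the halogen sits, so the estimate rests on a single step and carries a real chance that compound 4, like compound 1, returns only a limit.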

Compound 4, half-maximal inhibitory concentration: 22500 nM
Compound 4: middle estimate off by 1.2-fold (0.06 log units), on the high side, and the stated range covers the measured number.
By their numbers in this assay, from the lowest: compounds 2, 4 and 3 (each within the scatter of the next). At a limit, above all of these: compound 1.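

The step of an at least 2.2-fold lower number from compound 1 to compound 4 (0.34 log units; beyond the scatter) shows that leaving the limit at this aromatic nitrogen is not confined to 4-fluorophenyl, since a second aryl group in place of benzyl, here 2-bromophenyl, does the same. Changing the aryl group itself gives no readable difference, with a 1.1-fold lower number from compound 3 to compound 4 (0.02 log units; within the scatter), and the aryl group also cannot be told apart from (methoxycarbonyl)methyl, with a 1.1-fold higher number from compound 2 to compound 4 (0.02 log units; within the scatter). Compound 1 remains the only compound held at a limit, and each step from it is therefore a floor: the limit of > 50000 nM in this assay, at which 1 of the 4 values shown sits.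

It remains open whether the kind of halogen or its place on the phenyl ring matters at all, as no two compounds shown keep one fixed while the other changes, and whether an unsubstituted phenyl would also leave the limit. Going by these compounds, it is equally open whether an amine or a carboxylic acid on the aryl ring, or a longer chain in place of (methoxycarbonyl)methyl, would move the number away from the values shared by compound 2, compound 3 and compound 4.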